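This account rests on a few compounds, and the source may have more. Where it says the series, first, only, none or still open, it means among the compounds named here.

Measured so far:
- compound 1, `Oc1ccc(-c2cc(-c3ccccc3O)cc(-c3cccc(O)c3)n2)cc1`: 5650 nM
- compound 2, `Oc1ccc(-c2cc(-c3cccc(O)c3)cc(-c3cccc(O)c3)n2)cc1`: 1560 nM

In an ADME assay on HEK293 cells (Homo sapiens) for cytotoxicity, read by CCK-8 assay, with a stated time of 4 days (a higher number here means a weaker inhibitor, a lower number a stronger inhibitor), compound 2 stands at the lowest of the two numbers; the nearest is compound 1, and the step of a 3.6-fold lower number from compound 1 to compound 2 (0.56 log units; beyond the scatter) lies beyond the scatter. That step exchanged the two hydroxyphenyl patterns on the shared core: 3-hydroxyphenyl in place of 2-hydroxyphenyl on an aromatic carbon.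

Compound 3, `Oc1ccc(-c2cc(-c3cccc(O)c3)cc(-c3ccccc3O)n2)cc1`, has not been measured in this assay. It differs from compound 2 by 2-hydroxyphenyl in place of 3-hydroxyphenyl on an aromatic carbon, so the same two groups are swapped again, this time at the carbon next to the ring nitrogen. Among the measured compounds shown here, the only measured step that bears on it is a 3.6-fold lower number from compound 1 to compound 2 (0.56 log units; beyond the scatter), which ran in the opposite direction of the exchange. Reversing that exchange, though at a different carbon of the core, suggests a rise rather than a fall, of a size comparable to the measured step, with the different place adding uncertainty.

For compound 3 the number in this assay is therefore expected to lie around 3500 nM, within 1500 nM to 9000 nM, an expected step of a 2.2-fold higher number from compound 2 to compound 3 (0.35 log units; beyond the scatter).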

Compound 3, half-maximal inhibitory concentration: > 50000 nM
Compound 3 ended at the assay's limit (the forecaster's own chance of this, stated with the estimate: 5%); at least 14-fold (1.15 log units) between middle value and limit.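

Working notes on the series: in this assay, the exchange at the carbon next to the ring nitrogen carries far more weight than its small structural change suggests, with an at least 32-fold higher number from compound 2 to compound 3 (1.50 log units; beyond the scatter), and the entering and leaving groups are the same in atom count, donors and acceptors. Among the compounds shown here, compound 3 stands at a limit of the assay and not at a number, so this step fixes only a minimum size: the limit of > 50000 nM in this assay, at which 1 of the 3 values shown sits. Set beside a 3.6-fold lower number from compound 1 to compound 2 (0.56 log units; beyond the scatter), made at a different carbon of the shared core, the three compounds show 2-hydroxyphenyl going with the higher number at both carbons, with no compound against this, and the larger step at the carbon next to the ring nitrogen.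

The compounds shown leave open whether this step follows the hydroxyl itself or any group at that spot on the phenyl ring, which a 2-methoxyphenyl, 2-aminophenyl or unsubstituted phenyl group at this carbon would separate. They also leave open how far the limit of compound 3 lies from its true value, and whether the same order holds outside this one cell line.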